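This account rests on a few compounds, and the source may have more. Where it says the series, first, only, none or still open, it means among the compounds named here.

In an in vitro assay on HEK-tsA201 cells for antagonist activity at Neuronal acetylcholine receptor; alpha4/beta2 (Homo sapiens), read by fluorescence and calcium flux (on this read-out higher numbers stand for weaker inhibition and lower numbers for stronger inhibition), compound 1 `C=CCOc1ccc(C(=O)Nc2cccc(C)n2)cc1` gives 6000 nM, compound 2 `C=C(C)COc1ccc(C(=O)Nc2cccc(C)n2)cc1` gives 19600 nM and compound 3 `C=CCOc1ccc(C(=O)Nc2ccccn2)cc1` gives 19300 nM. Compound 3 thus stands second highest of the three numbers, close to compound 2 and well above compound 1. Compound 4 `C=CCOc1ccc(C(=O)Nc2cccc(Br)n2)cc1` differs from compound 3 by bromo in place of hydrogen on an aromatic carbon. The measured step that bears on this change is the one at the same aromatic carbon, where a 3.2-fold higher number from compound 1 to compound 3 (0.51 log units; beyond the scatter); the step along the chain, a 3.3-fold higher number from compound 1 to compound 2 (0.51 log units; beyond the scatter), concerns another place. A substituent at this carbon therefore seems likely to bring the number down, and compound 4 is expected to show a 2.4-fold lower number from compound 3 to compound 4 (0.38 log units; beyond the scatter). The value of compound 4 is estimated at 8000 nM, with a range from 3000 nM to 25000 nM.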

Compound 4, half-maximal inhibitory concentration: 70100 nM
For compound 4 the middle estimate is 8.8-fold (0.94 log units) below the measured one, outside the stated range (above it).
By their numbers in this assay, from the lowest: compound 1; then compounds 3 and 2 (each within the scatter of the next); then compound 4.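

At this aromatic carbon next to the ring nitrogen, a substituent as such does not bring the number down: bromo in place of hydrogen gives a 3.6-fold higher number from compound 3 to compound 4 (0.56 log units; beyond the scatter) and so runs opposite to methyl, which stands lower than hydrogen here. Bromo in place of methyl gives a 12-fold higher number from compound 1 to compound 4 (1.07 log units; beyond the scatter) and so separates the two groups widely at this one place. The data offer no explanation for this difference. On these data alone, whether chloro, fluoro, methoxy or an amine at this carbon would follow methyl or bromo stays open. So does whether bromo would act the same way with the methyl-bearing chain of compound 2.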